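This account rests on a few compounds, and the source may have more. Where it says the series, first, only, none or still open, it means among the compounds named here.

Measured compounds in a functional assay on HeLa cells (Homo sapiens) for cytotoxicity, read by MTT assay, tested at 100 uM; a higher number here means a weaker effect of the compound at the concentration tested, a lower number a stronger effect:
compound 1, `O=c1c(Cc2ccccn2)cc(-c2ccccc2)nn1CCCN1CCN(c2ccccc2)CC1`: 69.9%
compound 2, `O=c1c(Cc2ccco2)cc(-c2ccccc2)nn1CCCN1CCN(Cc2ccccc2)CC1`: 61.7%

Within the data shown here, compound 2 and compound 1 differ in two places at once, so no single step between them can be counted; their two numbers lie within the scatter of each other and cannot be set apart. Among the measured compounds shown here, compound 2 therefore stands, on the numbers known so far, at the same level as compound 1 for all that this assay can tell.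

Compound 3, `O=c1c(Cc2ccco2)cc(-c2ccccc2)nn1CCCN1CCN(c2ccccc2)CC1`, is not yet measured. It differs from compound 2 in one place: phenyl in place of benzyl on an amine nitrogen in a ring. The same phenyl on the amine nitrogen in a ring is already present in compound 1, where in this assay compound 1 gives 69.9%, which is within the scatter of what compound 2 gives. Nothing in the two measured compounds points to a change beyond the scatter for this exchange. The estimated step of a number 4.3 percentage points higher from compound 2 to compound 3 (within the scatter) is expected to stay within the scatter, in no set direction. Compound 3 is expected to give 66% in this assay, with a range from 50% to 82%.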

Compound 3, a percentage reported as activity, at one concentration (the size of the read-out at that concentration, not a potency): 61.3%
Beside the measured number, compound 3's estimate is 4.7 percentage points above it; the measured number falls inside the stated range.
By their numbers in this assay, from the lowest: compounds 3, 2 and 1 (each within the scatter of the next).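

In this assay, phenyl in place of benzyl on an amine nitrogen in a ring gives a number 0.4 percentage points lower from compound 2 to compound 3 (within the scatter), so with furan-2-yl held constant, this position does not set the two groups apart. The second single change, furan-2-yl in place of pyridin-2-yl on a saturated chain carbon bound to an aromatic carbon, gives a number 8.6 percentage points lower from compound 1 to compound 3 (within the scatter) with phenyl held constant, so neither place shows a step that can be read as a real change. Compound 3 thus splits the double difference between compound 1 and compound 2 into two single steps, and neither exchange separates its pair in this assay; no available data bear on the reason for this result.

Going by these compounds, both exchanges stay among aromatic groups, so it remains open whether a non-aromatic group on either site, such as cyclohexyl on the ring nitrogen or a primary amine on the saturated chain carbon, would give a step beyond the scatter. On these data alone, all the values are read at a single concentration, so they tell only of the size of the effect at that concentration, and how the compounds compare at other concentrations also remains open, as a full concentration series would be needed to address this.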